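Adding a second allyl group to a chromone antagonist

A few compounds are considered here, and "the series" means these few. Any claim that something is new, unique, unknown or untested is made for them only; others in the source may bear on it.

Of the compounds shown here, three have been measured in a functional assay on ileum (Cavia porcellus) for antagonist activity, with a stated time of 30 s; a lower number here means a stronger inhibitor, a higher number a weaker inhibitor. Compound 1 `CC(=O)c1ccc(OCC(O)COc2ccc3c(=O)cc(C(=O)O)oc3c2)cc1O` gives 28 ug/mL. Compound 2 `C=CCc1c(OCC(O)COc2ccc3c(=O)cc(C(=O)O)oc3c2)ccc(C(C)=O)c1O` gives 0.1 ug/mL, and compound 3 `C=CCc1c(OCC(O)COc2ccc(C(C)=O)c(O)c2)ccc2c(=O)cc(C(=O)O)oc12` gives 3.3 ug/mL, which puts compound 3 second highest of the three numbers, nearer to compound 1 than to compound 2.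

Compound 4 `C=CCc1c(OCC(O)COc2ccc3c(=O)cc(C(=O)O)oc3c2CC=C)ccc(C(C)=O)c1O` differs from compound 3 by allyl in place of hydrogen on an aromatic carbon. A change of the same kind, allyl in place of hydrogen on an aromatic carbon at the acetyl-bearing ring, separates compound 1 from compound 2, and there it gave a 280-fold lower number from compound 1 to compound 2 (2.45 log units; beyond the scatter). The other measured step, allyl in place of hydrogen on an aromatic carbon of the shared core, gave an 8.5-fold lower number from compound 1 to compound 3 (0.93 log units; beyond the scatter), and it is the change that already separates compound 1 from compound 3.

On this basis a large fall in the number is expected for compound 4, roughly a 170-fold lower number from compound 3 to compound 4 (2.22 log units; beyond the scatter), though the two allyl groups may not add up fully. The estimate for compound 4 in this assay is 0.02 ug/mL, with a range from 0.004 ug/mL to 0.1 ug/mL.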

Compound 4, half-maximal inhibitory concentration: 0.05 ug/mL
The estimate for compound 4 lay 2.5-fold (0.40 log units) below the measured number, and the stated range covers the measured number.
By their numbers in this assay, from the lowest: compounds 4 and 2 (each within the scatter of the next); then compound 3; then compound 1.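

In this assay, an allyl group on the acetyl-bearing ring, ortho to a hydroxy group, still brings a large gain when the shared core already carries an allyl group, with a 66-fold lower number from compound 3 to compound 4 (1.82 log units; beyond the scatter). The size of this step nevertheless depends on the core, so the two allyl groups do not simply add up: the same change on two cores in this assay, a 280-fold lower number (2.45 log units; beyond the scatter) from compound 1 to compound 2 and a 66-fold lower number (1.82 log units; beyond the scatter) from compound 3 to compound 4, 4.2-fold (0.63 log units) apart, beyond the scatter of two such steps. The allyl group on the core gives only a 2.0-fold lower number from compound 2 to compound 4 (0.30 log units; within the scatter), which leaves compound 2 and compound 4 within the scatter of each other, so its clear gain on compound 1 does not carry over once the other allyl group is present: the same change on two cores in this assay, an 8.5-fold lower number (0.93 log units; beyond the scatter) from compound 1 to compound 3 and a 2.0-fold lower number (0.30 log units; within the scatter) from compound 2 to compound 4, 4.2-fold (0.63 log units) apart, beyond the scatter of two such steps.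

These four compounds leave open whether this position needs the double bond of the allyl group or would accept a saturated propyl chain, a longer chain or a methoxy group. They also leave open whether the allyl steps would keep their size with an ester in place of the carboxylic acid.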